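Notes on an aryl group change in the series

The source may report more compounds than this note shows. Statements on the series, on what has been measured and on what is new or still open speak of the compounds shown alone.

Measured so far in a functional assay on MCF7 cells (Homo sapiens) for antiproliferative activity, read by MTT assay, with a stated time of 72 h; on this read-out higher numbers stand for weaker inhibition and lower numbers for stronger inhibition
- compound 1 `Nc1nc(N)c2cc(CSC(=S)N3CCN(c4ccccc4)CC3)ccc2n1` gives 2950 nM
- compound 2 `Cc1ccc(N2CCN(C(=S)SCc3ccc4nc(N)nc(N)c4c3)CC2)c(C)c1` gives 3120 nM

Compound 2 at 3120 nM cannot be told apart from compound 1 on these numbers, and the two values lie within the scatter of each other. The next entry is compound 3 `Nc1nc(N)c2cc(CSC(=S)N3CCN(c4ccc(F)cc4F)CC3)ccc2n1`, still unmeasured. It carries 2,4-difluorophenyl in place of 2,4-dimethylphenyl on an amine nitrogen in a ring, the difference being 2,4-difluorophenyl in place of 2,4-dimethylphenyl on an amine nitrogen in a ring in full.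

Among the compounds with values here, one measured step bears on this place, namely a 1.1-fold higher number from compound 1 to compound 2 (0.02 log units; within the scatter) for 2,4-dimethylphenyl in place of phenyl on the same nitrogen. That step stays within the scatter. Within the data shown here, no compound with a fluorine-bearing group has been measured, which leaves this single step as a weak guide. The expectation in this assay is therefore no step beyond the scatter, with no direction to call. The estimate means a 1.1-fold lower number from compound 2 to compound 3 (0.05 log units; within the scatter) as the expected step. Compound 3 is expected at 2800 nM with an estimated range from 1000 nM to 7000 nM for this read-out.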

Compound 3, half-maximal inhibitory concentration: 3670 nM
For compound 3 the middle estimate is 1.3-fold (0.12 log units) below the measured one; measured number inside the range.
By their numbers in this assay, from the lowest: compounds 1, 2 and 3 (each within the scatter of the next).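

In this assay, replacing the methyl-bearing aryl group with the fluorine-bearing one gives a 1.2-fold higher number from compound 2 to compound 3 (0.07 log units; within the scatter), and the comparison with plain phenyl gives a 1.2-fold higher number from compound 1 to compound 3 (0.09 log units; within the scatter). With compound 3, this position on an amine nitrogen in a ring has held phenyl, 2,4-dimethylphenyl and 2,4-difluorophenyl, and the exchange of 2,4-dimethylphenyl (8 carbon) for 2,4-difluorophenyl (6 carbon, 2 fluorine) at the same heavy-atom count leaves every printed step within the scatter, so these three aryl groups are not separated by this read-out. No supporting data are available to account for this result.

Still open, as far as these compounds go, is whether any group of a different kind at this nitrogen, such as a benzyl group, a pyridyl ring or a phenyl ring bearing a carboxylic acid, would give a step beyond the scatter. The three compounds also share the same core and the same sulfur-bearing link to the six-membered ring with 2 nitrogen, so they say nothing about how changes at those places would read in this assay.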